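This account rests on a few compounds, and the source may have more. Where it says the series, first, only, none or still open, it means among the compounds named here.

Compound 1, `FC(F)(F)c1cccc(-c2nc3cnc(Nc4ncccn4)cc3[nH]2)c1`: < 5000 nM
Compound 2, `N#Cc1ccc(Nc2cc3[nH]c(-c4cccc(C(F)(F)F)c4)nc3cn2)nc1`: < 5000 nM

In a physicochemical assay for solubility, using the shake flask method, in phosphate buffer, measured as kinetic solubility, with a stated time of 20 h, at pH 6.5 (on this read-out lower numbers stand for lower solubility and higher numbers for higher solubility), compound 1 gives only < 5000 nM, which is a limit of the assay and not a number. Compound 2 likewise gives only a limit in this assay, < 5000 nM. Going by the values given here, the single measured step, a step that the two limits leave unreadable from compound 1 to compound 2, is therefore of unreadable size. Compound 3, `FC(F)(F)c1cccc(-c2nc3cnc(Nc4ccc(-c5nnn[nH]5)cn4)cc3[nH]2)c1`, differs from compound 2 by 1H-tetrazol-5-yl in place of cyano on an aromatic carbon. Among the compounds with values here, no measured step bears on this change, and the only evidence is the limit of < 5000 nM in this assay, at which 2 of the 2 values shown sit, so neither direction nor size can be read from it. Compound 3 is expected to give 4000 nM, within a range of 1000 nM to 15000 nM. That amounts to an expected step that the limit leaves unreadable from compound 2 to compound 3, not beyond the scatter.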

Compound 3, solubility: < 5000 nM
Compound 3 ended at the assay's limit (the forecaster's own chance of this, stated with the estimate: 55%); the middle value lies beyond the limit too.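

Compound 2 and compound 3 both end at a limit of this assay, not at a number, so no new step can be read between them: the limit of < 5000 nM in this assay, at which 3 of the 3 values shown sit. The compounds shown leave open whether 1H-tetrazol-5-yl in place of cyano changes the read-out at all, and in which direction.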